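A Second Trifluoromethyl on the Amide Aryl Ring

A few compounds are considered here, and "the series" means these few. Any claim that something is new, unique, unknown or untested is made for them only; others in the source may bear on it.

Measured so far:
Compound 1, `COc1cc(Cl)cc(-c2nn(-c3cccc(NC(=O)c4ccc(Cl)c(Cl)c4)c3)cc2-c2ccncc2)c1`, gives 84.2% in a functional assay on UACC-257 cells (Homo sapiens) for inhibition, read by sulforhodamine B assay, with a stated time of 48 h, tested at 10 uM; on this read-out lower numbers stand for a stronger effect and higher numbers for a weaker effect at the one concentration tested.
Compound 2, `COc1cc(Cl)cc(-c2nn(-c3cccc(NC(=O)c4cccc(C(F)(F)F)c4)c3)cc2-c2ccncc2)c1`, gives 68.7% in this assay.

Compound 2 has the lowest of the two numbers in this assay; its nearest neighbour is compound 1, and the step of a number 15.5 percentage points lower from compound 1 to compound 2 (beyond the scatter) lies beyond the scatter. Compound 3, `COc1cc(Cl)cc(-c2nn(-c3cccc(NC(=O)c4cc(C(F)(F)F)cc(C(F)(F)F)c4)c3)cc2-c2ccncc2)c1`, differs from compound 2 in one place: trifluoromethyl in place of hydrogen on an aromatic carbon. Among the compounds with values here, only one measured step bears on this change, the one in which a trifluoromethyl-bearing ring replaced a dichloro-bearing one, a number 15.5 percentage points lower from compound 1 to compound 2 (beyond the scatter), a modest lowering. Adding a second trifluoromethyl to the same ring is a smaller change than that exchange, so a step in the same direction, at most modest or within the scatter, is expected in this assay. For compound 3 the estimate is 61%, between 42% and 82%. The expected step from compound 2 is a number 7.7 percentage points lower from compound 2 to compound 3 (within the scatter).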

Compound 3, a percentage reported as activity, at one concentration (the size of the read-out at that concentration, not a potency): 79.3%
For compound 3 the middle estimate is 18.3 percentage points below the measured one; the range from low to high includes it.
By their numbers in this assay, from the lowest: compound 2; then compounds 3 and 1 (each within the scatter of the next).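

In this assay, the second trifluoromethyl, placed on the amide aryl ring meta to a trifluoromethyl group, gives a number 10.6 percentage points higher from compound 2 to compound 3 (beyond the scatter). This step runs against the direction of a number 15.5 percentage points lower from compound 1 to compound 2 (beyond the scatter), so the lower number seen with a single trifluoromethyl on this ring does not carry over when a second one enters. At this position, then, hydrogen gives the lower number of the pair, and adding trifluoromethyl weakens the effect at the one concentration tested. Nothing available explains this reversal.

The compounds shown leave open whether the weaker effect is particular to trifluoromethyl or extends to other groups at this position, such as a methoxy group, a nitrile or an amine. They also leave open whether the same step would appear on another core.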